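The source may hold more compounds than are shown below. What is called first, only, known or untested is meant among the compounds shown, and "the series" means these compounds.

Compound 1, `C=C(c1ccc(OC)cc1NC(=O)CNC)c1ccc(OC)c2c1OC(C)(C)C=C2`, gives 400 nM.
Compound 2, `C=C(c1ccc(OC)cc1NC(=O)CNCC)c1ccc(OC)c2c1OC(C)(C)C=C2`, gives 2100 nM.
Compound 3, `C=C(c1cc(OC)c(OC)c(OC)c1)c1ccc(OC)c(O)c1NC(=O)COC`, gives 560 nM.

All three were tested in a functional assay on MCF7 cells (Homo sapiens) for antiproliferative activity, read by MTT assay, with a stated time of 48 h; on this read-out lower numbers stand for stronger inhibition and higher numbers for weaker inhibition. Compound 1 and compound 2 share one core and differ only by methyl in place of hydrogen on a saturated chain carbon bound to an amine nitrogen; this change produced a 5.3-fold higher number from compound 1 to compound 2 (0.72 log units; beyond the scatter). Compound 3 is built on another core, and how its core differs from that of compound 1 is not broken down here. Compound 4, `C=C(c1cc(OC)c(OC)c(OC)c1)c1ccc(OC)c(O)c1NC(=O)COCC`, has not yet been measured. It differs from compound 3 by methyl in place of hydrogen on a saturated chain carbon bound to an oxygen on a saturated carbon. Within the data shown here, that is the same kind of change as the one between compound 1 and compound 2, but the place is not the same: there the carbon is bound to an amine nitrogen, here to an oxygen on a saturated carbon. For compound 4 a weakening step of a 2.5-fold higher number from compound 3 to compound 4 (0.40 log units; beyond the scatter) is expected, resting on the measured 5.3-fold higher number from compound 1 to compound 2 (0.72 log units; beyond the scatter) and tempered by the different surroundings. Compound 4 is therefore estimated at 1400 nM in this assay, most likely between 500 nM and 4000 nM.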

Compound 4, half-maximal inhibitory concentration: 1050 nM
Estimate against measurement, compound 4: 1.3-fold (0.12 log units) above; measured number inside the range.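

In this assay, turning methoxymethyl into ethoxymethyl gives a 1.9-fold higher number from compound 3 to compound 4 (0.27 log units; within the scatter), so on this core the added methyl has no effect that can be told apart from ordinary repeat variation. The same change therefore does not carry over with one size from one core to the other: the same change on two cores in this assay, a 5.3-fold higher number (0.72 log units; beyond the scatter) from compound 1 to compound 2 and a 1.9-fold higher number (0.27 log units; within the scatter) from compound 3 to compound 4, 2.8-fold (0.45 log units) apart, beyond the scatter of two such steps. This does not show whether the core or the place of the change accounts for the gap, as the carbon is bound to an amine nitrogen in one pair and to an oxygen on a saturated carbon in the other, and two pairs set no rule for the series.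

The compounds shown leave open how a longer chain, such as propoxymethyl, would fare on the core of compound 3. They also leave open whether an amine in place of the methoxymethyl group on that core would respond to the added methyl as compound 1 does.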